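The compounds below may be only part of what the source reports. "The series", "measured", "known", "first", "only" and "open" are said of these compounds alone.

Compound 1 `COc1cc(/C=C/C(=O)c2cccc(-n3cc(-c4ccc(Cl)cc4)[nH]c3=O)c2)cc(OC)c1OC` is the starting point. In a functional assay on CAKI-1 cells (Homo sapiens) for inhibition (on this read-out higher numbers stand for weaker inhibition of growth and lower numbers for stronger inhibition of growth), compound 1 is reported as "not active" (no number reported), so no number stands behind it. Two related compounds do carry numbers: compound 2 `O=C(/C=C/c1cccc(O)c1)c1cccc(-n2cc(-c3ccc(Cl)cc3)[nH]c2=O)c1` gives 1720 nM in this assay, and compound 3 `COc1ccc(-c2cn(-c3cccc(C(=O)/C=C/c4ccc(O)c(OC)c4)c3)c(=O)[nH]2)cc1` gives 4990 nM. Both differ from compound 1 in more than one place, so their values show only that the series can reach measurable inhibition. Compound 4 `COc1cc(/C=C/C(=O)c2cccc(-n3cc(-c4cc(OC)c(OC)c(OC)c4)[nH]c3=O)c2)cc(OC)c1OC` is made from compound 1 by one change, (3,4,5-trimethoxyphenyl in place of 4-chlorophenyl on an aromatic carbon). For the measured compounds named here, no measured pair shows the effect of such a swap, and compound 1 itself offers no number to step from, so any expectation rests on the weak showing of compound 1 alone. Compound 4 is expected to remain weak, with an estimated 15000 nM spanning 3000 nM to 60000 nM, and a fair chance that only a limit is reported.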

Compound 4, concentration for 50% growth inhibition: 2890 nM
Compound 4: the middle estimate sits 5.2-fold (0.72 log units) above what was measured; measured number below the stated range.
By their numbers in this assay, from the lowest: compounds 2, 4 and 3 (each within the scatter of the next, the first and the last beyond it).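

For the compounds shown here, compound 1 carries no number, so no step from it to compound 4 can be read. The compounds shown leave open what swapping 4-chlorophenyl for 3,4,5-trimethoxyphenyl does to growth inhibition. Nothing here explains the result.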